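The source may report more compounds than this note shows. Statements on the series, on what has been measured and on what is new or still open speak of the compounds shown alone.

Of the compounds shown here, two have numbers so far. In a functional assay on DU-145 cells (Homo sapiens) for antiproliferative activity, read by sulforhodamine B assay, with a stated time of 48 h (a lower number here means a stronger inhibitor of growth, a higher number a weaker inhibitor of growth), compound 1 `Nc1ccc(Nc2nc(NC3CCCC3)c3ccccc3n2)cc1` gives 18700 nM and compound 2 `N#Cc1ccc(Nc2nc(NCCCO)c3ccccc3n2)cc1` gives 18700 nM, which places compound 2 level with compound 1, within the scatter. Compound 3 `Nc1ccc(Nc2nc(NCCCO)c3ccccc3n2)cc1` differs from compound 2 by amino in place of cyano on an aromatic carbon. Within the data shown here, no measured pair isolates this change. The 4-aminophenyl group already appears in compound 1 at 18700 nM, so no shift beyond the scatter is expected in this assay. The expected change is a 1.2-fold higher number from compound 2 to compound 3 (0.07 log units; within the scatter). For compound 3 the estimate is 22000 nM, with an expected range of 9000 nM to 50000 nM.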

Compound 3, concentration for 50% growth inhibition: 20800 nM
Estimate against measurement, compound 3: 1.1-fold (0.02 log units) above; the measured number falls inside the stated range.
By their numbers in this assay, from the lowest: compounds 1, 2 and 3 (each within the scatter of the next).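

In this assay the swap of 4-cyanophenyl to 4-aminophenyl, with the 3-hydroxypropyl chain held, gives a 1.1-fold higher number from compound 2 to compound 3 (0.05 log units; within the scatter) and so shows no shift beyond the scatter at this position. With 4-aminophenyl held, 3-hydroxypropyl in place of cyclopentyl gives a 1.1-fold higher number from compound 1 to compound 3 (0.05 log units; within the scatter) and so also shows no shift beyond the scatter. No measurement at hand explains either result.

Still open, as far as these compounds go, is whether a carboxylic acid or a methoxy group in place of the amino group would move the number beyond the scatter. The same holds for a longer chain in place of 3-hydroxypropyl.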